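The source may hold more compounds than are shown below. What is called first, only, known or untested is meant among the compounds shown, and "the series" means these compounds.

In a functional assay on Fem-X cells (Homo sapiens) for cytotoxicity, read by MTT assay, with a stated time of 72 h (a higher number here means a weaker inhibitor, a lower number a stronger inhibitor), compound 1 (`COc1ccc(Nc2ccc3ccccc3n2)cc1`) gives 43000 nM as its value. Among the measured compounds shown here, its only measured neighbour is compound 2 (`Fc1ccc(Nc2ccc3ccccc3n2)cc1`), which gives 35000 nM and cannot be told apart from compound 1 on these numbers. Compound 3 (`COc1ccc(Nc2nc3ccccc3cc2-c2ccc(C)cc2)cc1`) keeps the methoxy group of compound 1 and differs from it by one change, 4-methylphenyl in place of hydrogen on an aromatic carbon in words 4-methylphenyl in place of hydrogen on an aromatic carbon. The measured data offer a single guide, a 1.2-fold lower number from compound 1 to compound 2 (0.09 log units; within the scatter) with fluoro in place of methoxy on an aromatic carbon, and that step concerns a different group at a different place. For the measured compounds named here, no measured pair adds a group where compound 3 carries its new one, so this step bears on the change only weakly. In this assay a modest step toward a lower number is expected, with no change at all remaining possible. The expected step is a 2.2-fold lower number from compound 1 to compound 3 (0.33 log units; beyond the scatter) as a rough estimate. For compound 3 the expected value is 20000 nM with an estimated range from 5000 nM to 60000 nM in this measurement.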

Compound 3, half-maximal inhibitory concentration: 65000 nM
For compound 3 the middle estimate is 3.3-fold (0.51 log units) below the measured one; the measured number lies above the stated range.
By their numbers in this assay, from the lowest: compounds 2, 1 and 3 (each within the scatter of the next).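

In this assay the step is a 1.5-fold higher number from compound 1 to compound 3 (0.18 log units; within the scatter), so 4-methylphenyl in place of hydrogen on this aromatic carbon leaves compound 3 indistinguishable from compound 1. Among the compounds shown here, this is the first reading at this position, two atoms from the ring nitrogen and ortho to a group of 9 heavy atoms, as the earlier pair of compound 1 and compound 2 concerned only the exchange of methoxy for fluoro. The carbon thus carries an entering group of 7 heavy atoms, with one six-membered aromatic ring of carbon only, and the number stays within the scatter of that of compound 1. No measurement at hand accounts for this outcome.

On these data alone, whether a small group on the same carbon, such as methyl, or a group of another kind, such as an amine or a carboxylic acid, would take the number beyond the scatter remains open. Also open, as far as these compounds go, is whether fluoro in place of methoxy would give the same result with 4-methylphenyl present, as a single step at this position is all that can be read so far.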